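The source may report more compounds than this note shows. Statements on the series, on what has been measured and on what is new or still open speak of the compounds shown alone.

Measured so far in a functional assay on HCT-116 cells (Homo sapiens) for inhibition, with a stated time of 72 h; a lower number here means a stronger inhibitor, a higher number a weaker inhibitor:
- compound 1 `NC1CCC(Nc2nc(NCc3ccc(-c4ccccc4)cc3)c3ncn(C4CCCC4)c3n2)CC1`: 745 nM
- compound 2 `NC1CCC(Nc2nc(NCc3ccc(-c4cccc(F)c4)cc3)c3ncn(C4CCCC4)c3n2)CC1`: 551 nM

With so few numbers, compound 1 at 745 nM has a single measured neighbour, and that neighbour lies close: a 1.4-fold lower number from compound 1 to compound 2 (0.13 log units; within the scatter). The two compounds therefore cannot be told apart in this assay.

Compound 3 `NC1CCC(Nc2nc(NCc3ccc(-c4ccccc4)nc3)c3ncn(C4CCCC4)c3n2)CC1` keeps the core of compound 1 and changes one group: 6-phenylpyridin-3-yl in place of 4-phenylphenyl on a saturated chain carbon bound to a nitrogen on an aromatic ring. In words, 6-phenylpyridin-3-yl stands in place of 4-phenylphenyl, on a saturated chain carbon bound to a nitrogen on an aromatic ring.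

Going by the values given here, only one measured step touches this group, and it is a different kind of change, fluoro in place of hydrogen on an aromatic carbon. Among the compounds with values here, no measured compound carries the new ring, so the data give no direct guide and no firm direction. Going by the small size of that one step, a 1.4-fold lower number from compound 1 to compound 2 (0.13 log units; within the scatter), no shift beyond the scatter is expected, though this is weak support.

The expected step is small: a 1.1-fold higher number from compound 1 to compound 3 (0.03 log units; within the scatter). For compound 3 the estimated value is 800 nM, with an expected range of 300 nM to 2000 nM.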

Compound 3, half-maximal inhibitory concentration: 563 nM
For compound 3 the middle estimate is 1.4-fold (0.15 log units) above the measured one; the range from low to high includes it.
By their numbers in this assay, from the lowest: compounds 2, 3 and 1 (each within the scatter of the next).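

In this assay, placing 6-phenylpyridin-3-yl in place of 4-phenylphenyl on a saturated chain carbon bound to a nitrogen on an aromatic ring gives a 1.3-fold lower number from compound 1 to compound 3 (0.12 log units; within the scatter), so the assay does not tell these two groups apart. The swap keeps the same number of heavy atoms, turns one six-membered aromatic ring of carbon only into a ring with a hetero atom, and brings in a hydrogen-bond acceptor, yet the result stays within the scatter; at this position, then, this particular change produces no readable shift in the cell result. No supporting measurement is available to explain this outcome.

As far as these compounds go, all three compounds keep two six-membered aromatic rings in this group, so it remains open whether a smaller group such as plain phenyl, or an amine or a carboxylic acid attached to 4-phenylphenyl, would move the number beyond the scatter. From the compounds shown here alone, it is also open whether 6-phenylpyridin-3-yl carrying a fluoro group, which would join the changes seen in compound 2 and compound 3, would behave any differently.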